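Two amines on a shared core, and a smaller third

The compounds below may be only part of what the source reports. "The series", "measured", "known", "first", "only" and "open" are said of these compounds alone.

Measured in a functional assay (aorta) with Rattus norvegicus as the target; a lower number here means a stronger inhibitor, a higher number a weaker inhibitor:
Compound 1 `CC(C)c1cn2ccccc2c1S(=O)(=O)c1ccc(OCCCN2CCN(c3ccccc3)CC2)cc1` gives 205 nM
Compound 2 `COc1ccc(NCCCOc2ccc(S(=O)(=O)c3c(C(C)C)cn4ccccc34)cc2)cc1OC` gives 396 nM

Among the compounds with values here, with only two measurements, compound 2 at 396 nM lies within the scatter of compound 1. The next structure is compound 3 `CC(C)c1cn2ccccc2c1S(=O)(=O)c1ccc(OCCCN(C)C)cc1` and the change is dimethylamino in place of (3,4-dimethoxyphenyl)amino on a saturated chain carbon, three bonds along the chain from an oxygen on an aromatic ring with dimethylamino in place of (3,4-dimethoxyphenyl)amino on a saturated chain carbon, three bonds along the chain from an oxygen on an aromatic ring. Within the data shown here, one measured step bears on this place, namely a 1.9-fold higher number from compound 1 to compound 2 (0.29 log units; within the scatter) and it exchanged one ring-carrying group for another. Among the measured compounds shown here, no measured step shows what happens in this assay when a small group without a ring enters here. The expected step is a 1.3-fold lower number from compound 2 to compound 3 (0.12 log units; within the scatter) and so no clear shift is expected, though with much uncertainty. Compound 3 is therefore expected near 300 nM (estimated range 90 nM to 1000 nM).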

Compound 3, half-maximal inhibitory concentration: 390 nM
Compound 3: middle estimate off by 1.3-fold (0.11 log units), on the low side, within the range that was stated.
By their numbers in this assay, from the lowest: compounds 1, 3 and 2 (each within the scatter of the next).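

Compound 3 carries a much smaller group at this place, on a saturated chain carbon, three bonds along the chain from an oxygen on an aromatic ring. Dimethylamino has no ring, yet exchanging (3,4-dimethoxyphenyl)amino for it leaves the reading in this assay unchanged within the scatter (a 1.0-fold lower number from compound 2 to compound 3 (0.01 log units; within the scatter)), and the exchange of 4-phenylpiperazin-1-yl for dimethylamino also stays within the scatter (a 1.9-fold higher number from compound 1 to compound 3 (0.28 log units; within the scatter)). So among these three compounds, an aromatic ring on this amine is not required for a number in this range, and no order among them can be drawn, though nothing available explains this.

The compounds shown leave open whether this place needs a nitrogen at all, as a hydroxyl or a carboxylic acid there would test. They also leave open how a longer chain between the oxygen and the amine would read.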